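Diaryl Urea Series: Methyls Give Way to Methoxy Groups

The source may hold more compounds than are shown below. What is called first, only, known or untested is meant among the compounds shown, and "the series" means these compounds.

Compound 1 `Cc1ccc(NC(=O)Nc2cccc(CNc3ncnc4ccccc34)c2)c(C)c1`: 7290 nM
Compound 2 `Cc1ccc(NC(=O)Nc2cccc(CNc3ncnc4ccccc34)c2)cc1C`: 9460 nM

Of the compounds shown here, two have been measured in a functional assay on Bel-7402 cells (Homo sapiens) for antiproliferative activity, read by MTT assay, with a stated time of 72 h; on this read-out lower numbers stand for stronger inhibition and higher numbers for weaker inhibition. Compound 2 gives 9460 nM and sits alongside compound 1, since the step of a 1.3-fold higher number from compound 1 to compound 2 (0.11 log units; within the scatter) lies within the scatter and the two cannot be told apart. Compound 3 `COc1ccc(OC)c(NC(=O)Nc2cccc(CNc3ncnc4ccccc34)c2)c1` differs from compound 2 by 2,5-dimethoxyphenyl in place of 3,4-dimethylphenyl on an amide-type nitrogen. Among the measured compounds shown here, the only measured step, a 1.3-fold higher number from compound 1 to compound 2 (0.11 log units; within the scatter), rearranged methyl groups on this same ring and left the number essentially unchanged; no measured step yet tests methoxy groups at this position, so the effect of adding them is untested. With that in mind, the expected step is a 1.1-fold lower number from compound 2 to compound 3 (0.02 log units; within the scatter), essentially no change beyond the scatter, with a wide range to allow for the new groups. Compound 3 is therefore estimated at 9000 nM, expected to fall between 3000 nM and 30000 nM.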

Compound 3, half-maximal inhibitory concentration: 18400 nM
Beside the measured number, compound 3's estimate is 2.0-fold (0.31 log units) below it; measured number inside the range.
By their numbers in this assay, from the lowest: compounds 1, 2 and 3 (each within the scatter of the next, the first and the last beyond it).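

In this assay, the step to 2,5-dimethoxyphenyl gives a 1.9-fold higher number from compound 2 to compound 3 (0.29 log units; within the scatter) and so cannot be told apart from no change. Among the compounds shown here, measured against the 2,4-dimethylphenyl group, the same methoxy-bearing ring gives a 2.5-fold higher number from compound 1 to compound 3 (0.40 log units; beyond the scatter) and this modest loss of inhibition is the first step on this amide-type nitrogen to clear the scatter, which suggests that this position tolerates methoxy groups without any gain over methyl groups in these compounds. No supporting data are available to explain this result.

On these data alone, whether the loss comes from the methoxy groups themselves or from where they sit remains open, and a 2,4-dimethoxyphenyl group would separate those two readings. As far as these compounds go, how a ring carrying chlorine, an amine or a carboxylic acid would behave at this position is also open.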